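The source may report more compounds than this note shows. Statements on the series, on what has been measured and on what is new or still open speak of the compounds shown alone.

Measured compounds: compound 1, `COc1ccc(C(=O)/C=C/c2ccc(N(C)C)cc2)c2c1C=CC(C)(C)O2`, gives 3500 nM in a functional assay on K562 cells (Homo sapiens) for antiproliferative activity, read by MTT assay, with a stated time of 24 h; a lower number here means a stronger inhibitor, a higher number a weaker inhibitor. Compound 2, `COc1ccc(/C=C/C(=O)c2ccc(OC)c3c2OC(C)(C)C=C3)cn1`, gives > 10000 nM in this assay, and this is a limit of the assay rather than a number.

Compound 2 therefore stands at the limit of > 10000 nM in this assay, at which 1 of the 2 values shown sits, the weaker end of the two values shown. Going by the values given here, the only measured step, an at least 2.8-fold higher number from compound 1 to compound 2 (0.45 log units; beyond the scatter), changed the same place that changes again here. Compound 3, `COc1ccc(C(=O)/C=C/c2cccc(Cl)c2)c2c1C=CC(C)(C)O2`, differs from compound 2 by 3-chlorophenyl in place of 6-methoxypyridin-3-yl on a double-bonded chain carbon bound to a double-bonded chain carbon. Among the compounds with values here, no measured step tests a 3-chlorophenyl at this place, so the measured step sets the scale without fixing the direction. Compound 3 is expected to land near 8000 nM, within 3000 nM to 20000 nM, in this assay. This estimate amounts to an at least 1.2-fold lower number from compound 2 to compound 3 (0.09 log units; that floor lies within the scatter), with a fair chance that the assay again reports only a limit for compound 3.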

Compound 3, half-maximal inhibitory concentration: > 10000 nM
Compound 3: only a limit was reported; the forecaster's own chance of this, stated with the estimate: 40%; middle value at least 1.2-fold (0.09 log units) away from the limit.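

In this assay compound 3 gives > 10000 nM, and this is a limit of the assay. Placing 3-chlorophenyl in place of 4-(dimethylamino)phenyl on a double-bonded chain carbon bound to a double-bonded chain carbon gives an at least 2.8-fold higher number from compound 1 to compound 3 (0.45 log units; beyond the scatter), so a second group at this place also gives a clear loss against the 4-(dimethylamino)phenyl, while the step between compound 2 and compound 3 cannot be read. Of the three groups shown at this place, only the 4-(dimethylamino)phenyl of compound 1 gives a value that is a number and not a limit: the limit of > 10000 nM in this assay, at which 2 of the 3 values shown sit.

As far as these compounds go, how far compound 2 and compound 3 lie beyond that limit stays open, and neither can be ranked against the other. Also open, from the compounds shown here alone, is whether a phenyl carrying a plain amine or a diethylamino group at this place would match compound 1, at 3500 nM.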